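From compound 3 to compound 4: working notes

The source may hold more compounds than are shown below. What is called first, only, known or untested is meant among the compounds shown, and "the series" means these compounds.

In an ADME assay on MT4 cells (Homo sapiens) for cytotoxicity, read by MTT assay (on this read-out lower numbers stand for higher toxicity in this test and higher numbers for lower toxicity in this test), compound 1 `O=C(Nc1ccc(F)cc1)C1C(=O)N(O)C(=O)c2ccccc21` gives 115000 nM and compound 2 `O=C(NCc1ccccc1)C1C(=O)N(O)C(=O)c2ccccc21` gives 130000 nM. Compound 3 `Cc1ccc(CNC(=O)C2C(=O)N(O)C(=O)c3ccccc32)cc1` has only a limit, > 125000 nM, and not a number.

Compound 4 `O=C(NCc1ccc(O)cc1O)C1C(=O)N(O)C(=O)c2ccccc21` carries 2,4-dihydroxyphenyl in place of the 4-methylphenyl of compound 3, on a saturated chain carbon bound to an amide-type nitrogen: 2,4-dihydroxyphenyl in place of 4-methylphenyl on a saturated chain carbon bound to an amide-type nitrogen.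

Among the compounds with values here, three measured steps bear on this change. They are a 1.1-fold higher number from compound 1 to compound 2 (0.05 log units; within the scatter), an at least 1.0-fold higher number from compound 1 to compound 3 (0.03 log units; that floor lies within the scatter) and a step that the limit leaves unreadable from compound 2 to compound 3. None of the readable steps goes beyond the scatter, although none of them introduces this substituent.

The expected step in this assay is an at least 1.2-fold lower number from compound 3 to compound 4 (0.09 log units; that floor lies within the scatter), which would not go beyond the scatter. Compound 4 is estimated at 100000 nM, with an expected range of 35000 nM to 160000 nM.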

Compound 4, half-maximal cytotoxic concentration: > 125000 nM
Compound 4 ended at the assay's limit; the forecaster's own chance of this, stated with the estimate: 35%; at least 1.2-fold (0.09 log units) between middle value and limit.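

No new step can be read from compound 3 to compound 4 or from compound 2 to compound 4, because compound 4 gives only a limit: the limit of > 125000 nM in this assay, at which 2 of the 4 values shown sit.

The compounds shown leave open whether 2,4-dihydroxyphenyl in place of 4-methylphenyl or phenyl changes this read-out at all.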